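Moving the ring nitrogen: compound 2 to compound 3

This account rests on a few compounds, and the source may have more. Where it says the series, first, only, none or still open, it means among the compounds named here.

The series is built on one shared core, a cyclic ketone carrying two exocyclic double bonds, with a sulfonyl group on the ring nitrogen. Compound 1 `Cc1ccc(S(=O)(=O)N2C/C(=C\c3cccnc3)C(=O)/C(=C/c3ccccc3C(F)(F)F)C2)cc1` gives 6700 nM in a functional assay on SMMC-7721 cells (Homo sapiens) for cytotoxicity, read by MTT assay, with a stated time of 24 h; on this read-out higher numbers stand for weaker inhibition and lower numbers for stronger inhibition. Compound 2 `O=C1/C(=C/c2cccnc2)CN(S(=O)(=O)c2ccc(Cl)cc2)C/C1=C\c1ccccc1C(F)(F)F` gives 4880 nM in this assay. Going by the values given here, of the two numbers measured, compound 2 holds the lower one, but the only step recorded, a 1.4-fold lower number from compound 1 to compound 2 (0.14 log units; within the scatter), lies within the scatter, so the two compounds cannot be ranked against each other.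

Compound 3 `O=C1/C(=C/c2ccncc2)CN(S(=O)(=O)c2ccc(Cl)cc2)C/C1=C\c1ccccc1C(F)(F)F` has not yet been measured. It differs from compound 2 in one place: pyridin-4-yl in place of pyridin-3-yl on a double-bonded chain carbon bound to a double-bonded ring carbon. Among the compounds with values here, no measured step bears on this change, since the single recorded step concerns chloro in place of methyl on the aromatic carbon, a different part of the molecule, and that step was itself within the scatter. The expectation for compound 3 in this assay therefore rests on compound 2 alone, whose value 4880 nM is taken as the anchor, with no step beyond the scatter anticipated in either direction. The estimated step is a 1.0-fold higher number from compound 2 to compound 3 (0.00 log units; within the scatter). Compound 3 is thus estimated at 4900 nM, with a range from 1800 nM to 13000 nM.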

Compound 3, half-maximal inhibitory concentration: 5510 nM
For compound 3 the middle estimate is 1.1-fold (0.05 log units) below the measured one; low and high end bracket the measured number.
By their numbers in this assay, from the lowest: compounds 2, 3 and 1 (each within the scatter of the next).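

In this assay, pyridin-4-yl in place of pyridin-3-yl on a double-bonded chain carbon bound to a double-bonded ring carbon gives a 1.1-fold higher number from compound 2 to compound 3 (0.05 log units; within the scatter), the first step recorded at this position, so compound 2 and compound 3 cannot be ranked against each other. The change keeps the same atoms and alters only how they are joined, and here that difference in the pyridine ring leaves the two numbers within the scatter, which the earlier step at the aromatic carbon of the sulfonyl group could not show. Both single changes recorded so far, at two different places, now lie within the scatter, and no measurement at hand offers an explanation for the closeness of compound 2 and compound 3.

The compounds shown leave open whether pyridin-2-yl, or a ring of this size carrying a carboxylic acid or an amine, would give a step beyond the scatter at this position. They also leave open whether pyridin-4-yl would give a similar number with methyl in place of chloro on the aromatic carbon.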